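This account rests on a few compounds, and the source may have more. Where it says the series, first, only, none or still open, it means among the compounds named here.

Compound 1 `O=C(O)c1ccccc1-c1ccc(CCc2ncc(Cc3ccccc3F)[nH]2)cc1`: 9.5 nM in an in vitro functional assay on cells for agonist activity at Bombesin receptor subtype-3 (Mus musculus), read by luminescence and calcium flux; a higher number here means that more compound is needed for the effect, a lower number that less compound is needed
Compound 2 `CC(C)(C)CCc1cnc(CCc2ccc(-c3ccccc3C(=O)O)cc2)[nH]1`: 6.2 nM
Compound 3 `CCCCc1cnc(CCCc2ccc(-c3ccccc3C(=O)O)cc2)[nH]1`: 382 nM

Among these three, compound 2 gives the lowest number, though compound 1 lies within the scatter of it; compound 3, which differs from compound 2 in more than one place, gives a far higher number. Compound 4 `COc1cccc(Cc2cnc(CCc3ccc(-c4ccccc4C(=O)O)cc3)[nH]2)c1` carries 3-methoxyphenyl in place of neopentyl on a saturated chain carbon bound to an aromatic carbon. Going by the values given here, the one measured step that bears on this is a 1.5-fold lower number from compound 1 to compound 2 (0.19 log units; within the scatter), where an aromatic group gave way to neopentyl with no shift beyond the scatter. Putting an aromatic group back at the same place, now as 3-methoxyphenyl, is therefore expected to produce no step beyond the scatter: the expected outcome is a 1.3-fold higher number from compound 2 to compound 4 (0.11 log units; within the scatter). Compound 4 is estimated at 8 nM, within 3 nM to 25 nM.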

Compound 4, half-maximal effective concentration: 79 nM
Estimate against measurement, compound 4: 9.9-fold (0.99 log units) below; measured number above the stated range.
By their numbers in this assay, from the lowest: compounds 2 and 1 (each within the scatter of the next); then compound 4; then compound 3.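

Swapping the group at this place can matter a great deal: on a saturated chain carbon bound to an aromatic carbon, 3-methoxyphenyl brings a clear loss against neopentyl (a 13-fold higher number from compound 2 to compound 4 (1.11 log units; beyond the scatter)). Against 2-fluorophenyl the loss is smaller but still real (an 8.3-fold higher number from compound 1 to compound 4 (0.92 log units; beyond the scatter)), so one aromatic group here does not predict another. No evidence available here explains the difference.

The two aromatic groups differ in both substituent and ring location, so neither can be singled out. Plain phenyl or 3-fluorophenyl at this place would help separate them.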